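The compounds below may be only part of what the source reports. "The series", "measured", "known", "first", "only" and "open" are said of these compounds alone.

Compound 1 `C=C1C[C@]23C[C@@]1(O)CC[C@H]2c1ccc(OS(=O)(=O)c2ccc(C)cc2)c(C)c1[C@@H]3Cn1cc(-c2ccc(OC)cc2)nn1` and compound 2 `C=C1C[C@]23C[C@@]1(O)CC[C@H]2c1ccc(OS(=O)(=O)c2ccc(C)cc2)c(C)c1[C@@H]3Cn1cc(-c2ccc(C)cc2)nn1` share a core that carries a tosylate ester and a methyl-substituted phenyl ring, and both were tested in a functional assay on HL-60 cells (Homo sapiens) for cytotoxicity, read by MTT assay, with a stated time of 4 days; a lower number here means a stronger inhibitor, a higher number a weaker inhibitor. In this assay compound 1 gives only a limit, > 20000 nM. Compound 2 likewise gives only a limit, > 20000 nM. The two differ by methoxy in place of methyl on an aromatic carbon, and the step that the two limits leave unreadable from compound 2 to compound 1 cannot be read, since both values sit at the limit of > 20000 nM in this assay, at which 2 of the 3 values shown sit.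

Compound 3 `C=C1C(=O)[C@]23C[C@@]1(O)CC[C@H]2c1ccc(O)c(C)c1[C@@H]3Cn1cc(-c2ccc(C)cc2)nn1` rests on a different core, bearing a ketone and a free phenol; how its core differs from that of compound 2 is not broken down here. In this assay, among the compounds with values here, compound 3 gives 830 nM, the only number among the three values shown.

Compound 4 `C=C1C(=O)[C@]23C[C@@]1(O)CC[C@H]2c1ccc(O)c(C)c1[C@@H]3Cn1cc(-c2ccc(OC)cc2)nn1` carries the core of compound 3 and differs from it by methoxy in place of methyl on an aromatic carbon. Within the data shown here, this is the same change as the one from compound 2 to compound 1, made in the same surroundings, so the earlier pair offers no readable size for it. Among the measured compounds shown here, for compound 4 the expected step in this assay is a 1.2-fold higher number from compound 3 to compound 4 (0.08 log units; within the scatter), a modest one, anchored on compound 3 at 830 nM with no measured precedent for its direction. Compound 4 is therefore estimated at 1000 nM, with a plausible range from 300 nM to 3500 nM.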

Compound 4, half-maximal inhibitory concentration: 1150 nM
Compound 4: middle estimate off by 1.2-fold (0.06 log units), on the low side; the measured number falls inside the stated range.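

In this assay, replacing 4-methylphenyl with 4-methoxyphenyl on the core of compound 3 gives a 1.4-fold higher number from compound 3 to compound 4 (0.14 log units; within the scatter), so on this core the exchange of methyl for methoxy leaves the two compounds indistinguishable. The same change on the core of compound 2 cannot be read, because compound 1 and compound 2 each give a limit and not a number: the limit of > 20000 nM in this assay, at which 2 of the 4 values shown sit. Within the data shown here, the series therefore offers only one readable instance of this change, which shows how it reads on the core of compound 3 but not whether that result carries over to the tosylate core, where a difference of any size could lie hidden behind the limits.

The compounds shown leave open what other groups in this place on the aromatic ring would do, such as a chlorine, an amine or a carboxylic acid, as only methyl and methoxy stand there. No pair shown separates the ketone from the free phenol in the core of compound 3, so it remains open which of the two, if either, goes with the value of compound 3, 830 nM.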